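Removing one phenyl from the benzhydryl piperazine

The source may report more compounds than this note shows. Statements on the series, on what has been measured and on what is new or still open speak of the compounds shown alone.

Compound 1 `O=C(CN1CCC(c2ccccc2)(c2ccccc2)C1=O)N1CCN(C(c2ccccc2)c2ccccc2)CC1`: < 25000 nM.
Compound 2 `O=C(CN1CCC(c2ccccc2)(c2ccccc2)C1=O)N1CCN(C(c2ccccc2)c2ccc(Cl)cc2)CC1`: < 25000 nM.
Compound 3 `O=C(CN1CCC(c2ccccc2)(c2ccccc2)C1=O)N1CCN(C(c2ccccc2)c2ccc(F)cc2)CC1`: < 25000 nM.

In a physicochemical assay for solubility, at pH 7 (on this read-out lower numbers stand for lower solubility and higher numbers for higher solubility), the three measured compounds share the same core and differ only on one aromatic ring of the benzhydryl group. Compound 3 stands at a limit of this assay, not at a number, with < 25000 nM. Compound 2 likewise sits at a limit, with < 25000 nM. Compound 1 also sits at a limit, with < 25000 nM. The steps among them are therefore not readable: a step that the two limits leave unreadable from compound 1 to compound 2, a step that the two limits leave unreadable from compound 1 to compound 3 and a step that the two limits leave unreadable from compound 2 to compound 3. All that the measured set shows is the limit of < 25000 nM in this assay, at which 3 of the 3 values shown sit.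

Compound 4 `O=C(CN1CCC(c2ccccc2)(c2ccccc2)C1=O)N1CCN(Cc2ccc(F)cc2)CC1` has not yet been measured in this assay. It differs from compound 3 by hydrogen in place of phenyl on a saturated chain carbon bound to an amine nitrogen in a ring and an aromatic carbon. Among the measured compounds shown here, none of the measured steps touches this place, and none of them has a readable size, so there is no measured step that bears directly on it. Compound 4 is therefore expected to give about 20000 nM, with a range from 4000 nM to 100000 nM. That estimate means an expected step that the limit leaves unreadable from compound 3 to compound 4, which cannot be set against any readable step among the measured compounds.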

Compound 4, solubility: 57000 nM
Estimate against measurement, compound 4: 2.9-fold (0.45 log units) below; measured number inside the range.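

In this assay, hydrogen in place of phenyl on a saturated chain carbon bound to an amine nitrogen in a ring and an aromatic carbon gives an at least 2.2-fold higher number from compound 3 to compound 4 (0.35 log units; beyond the scatter). This place is therefore the only one in the set where a change has a readable direction, and that step lies beyond the scatter, whereas the steps among the three compounds that differ on the aromatic ring of the benzhydryl group cannot be read. Compound 4 is also the only compound shown that carries a number rather than a limit, so it alone stands clear of what the rest of the set shows: the limit of < 25000 nM in this assay, at which 3 of the 4 values shown sit.

Going by these compounds, the true size of the step stays open, since only its lower bound can be read, and a single change at a single place cannot show how much of the phenyl has to go for the number to rise. Also open, on these data alone, is whether methyl on the same saturated chain carbon would give a number like that of compound 4, and whether an amine or a carboxylic acid on the remaining aromatic ring would carry the number further.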